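Cytotoxicity notes on the sulfonyl acetamide series

The source may hold more compounds than are shown below. What is called first, only, known or untested is meant among the compounds shown, and "the series" means these compounds.

The series is read in an ADME assay on MRC5 cells (Homo sapiens) for cytotoxicity, read by MTT assay, with a stated time of 72 h; a higher number here means a weaker inhibitor of growth, a lower number a stronger inhibitor of growth. For the measured compounds named here, compound 1 `COc1ccc(CS(=O)(=O)CC(=O)Nc2c(C)cc(C)cc2C)cc1[N+](=O)[O-]` gives 28000 nM in this assay, and it is the only member with a number rather than a limit. Compound 2 `COc1ccc(CS(=O)(=O)CC(=O)Nc2c(C)cc(C)cc2C)cc1N` sits at the limit of this assay, > 30000 nM, which is a limit and not a number (the limit of > 30000 nM in this assay, at which 1 of the 2 values shown sits). Going by the values given here, the single measured step, an at least 1.0-fold higher number from compound 1 to compound 2 (0.02 log units; that floor lies within the scatter), changes the group on the aromatic carbon and lies within the scatter.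

Compound 3 `COc1ccc(CS(=O)(=O)CC(=O)Nc2ccccc2)cc1[N+](=O)[O-]` is the next structure: phenyl in place of 2,4,6-trimethylphenyl on an amide-type nitrogen. No measured step touches the amide-type nitrogen, so the one step shown, from nitro to amino, bears on this change only by showing that a replacement elsewhere on compound 1 left the readout where it was. On that basis no step beyond the scatter is expected in this assay, in either direction, and compound 3 is expected to remain near compound 1, with a fair chance of returning only a limit. The expected step is a 1.1-fold higher number from compound 1 to compound 3 (0.03 log units; within the scatter). The estimate for compound 3 in this assay is 30000 nM, within 12000 nM to 75000 nM.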

Compound 3, concentration for 50% growth inhibition: > 30000 nM
Compound 3 ended at the assay's limit (the forecaster's own chance of this, stated with the estimate: 45%); the middle value lies on the limit itself.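

Phenyl in place of 2,4,6-trimethylphenyl on an amide-type nitrogen gives an at least 1.0-fold higher number from compound 1 to compound 3 (0.02 log units; that floor lies within the scatter) in this assay, the first reading of any change at this position. The printed step is only a floor, so its full size cannot be read, but the loss of the trimethylphenyl methyl groups brings no number lower than that of compound 1; the amide-type nitrogen thus joins the nitro-to-amino change as a second place on compound 1 where a replacement produces no step beyond the scatter. With compound 3, the series now gathers further at the top of the measurable range, and a limit says only that the value lies beyond what this reading can resolve: the limit of > 30000 nM in this assay, at which 2 of the 3 values shown sit.

What remains open is whether anything on the amide-type nitrogen can bring the readout well under compound 1, since a phenyl carrying a carboxylic acid or an amine, or a longer alkyl chain in place of the aromatic ring, does not appear among these compounds. The pairing of phenyl on that nitrogen with amino in place of nitro also stands outside the compounds shown, so whether the two changes together stay at the limit cannot be said.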